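This account rests on a few compounds, and the source may have more. Where it says the series, first, only, none or still open, it means among the compounds named here.

Working notes on the salicylanilide set. The series is followed in a functional assay on KG-1 cells (Homo sapiens) for cytotoxicity, read by luminescence and CellTiter-Glo, with a stated time of 3 days; a lower number here means a stronger inhibitor, a higher number a weaker inhibitor. Compound 1 `O=C(Nc1ccc(C(F)(F)F)cc1)c1cc(Cl)c(-c2ccccc2)cc1O` gives 770 nM in this assay. Compound 2 `N#Cc1ccc(NC(=O)c2cc(Cc3ccccc3)ccc2O)cc1` gives 1930 nM in this assay, and compound 3 `O=C(Nc1cc(Cl)cc(Cl)c1)c1cc(F)ccc1O` gives 780 nM in this assay. Among these three numbers compound 2 stands highest; its nearest neighbour is compound 3, whose number is lower by a margin beyond the scatter, and compound 1 also sits lower by a margin beyond the scatter. Among the measured compounds shown here, none of the three measured compounds differs from another in one place only, so no single-point step is available within the measured set.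

The next compound, compound 4 `N#Cc1ccc(NC(=O)c2cc(-c3cccnc3)ccc2O)cc1`, is to be measured in this assay. Compound 4 differs from compound 2 in one place: pyridin-3-yl in place of benzyl on an aromatic carbon. For the measured compounds named here, no measured pair in the set isolates a change of this kind, so the expectation rests on the general level of the three numbers rather than on a direct precedent. The step is expected to be small, most likely a modest move toward a lower number. The expected step is a 1.4-fold lower number from compound 2 to compound 4 (0.14 log units; within the scatter). Compound 4 is therefore estimated at 1400 nM in this assay, with a range from 450 nM to 4500 nM.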

Compound 4, half-maximal inhibitory concentration: 8330 nM
Beside the measured number, compound 4's estimate is 6.0-fold (0.77 log units) below it; the whole stated range lies below it.
By their numbers in this assay, from the lowest: compounds 1 and 3 (each within the scatter of the next); then compound 2; then compound 4.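

Working notes, continued. Among the compounds shown here, with benzyl replaced by pyridin-3-yl on the aromatic carbon para to a hydroxy group, this assay shows a 4.3-fold higher number from compound 2 to compound 4 (0.64 log units; beyond the scatter), the first single-point step. For the compounds shown here, the earlier compounds offered no such pair, so this step is the first sign that the number in this assay depends on the group at this position, and here the entering pyridin-3-yl, with its ring nitrogen and hydrogen-bond acceptor, goes with the higher number. No measurement in hand explains the rise.

Still open, as far as these compounds go, is which part of the exchange goes with the step, since the methylene link of benzyl leaves and the ring nitrogen enters together; a plain phenyl on this carbon, with the rest of compound 4 unchanged, would separate the two. How far the trend extends is also unsettled, as a single pair gives no direction for other groups at this position, such as a morpholine, a carboxylic acid or a longer alkyl chain.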